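Two Chlorophenyl Amides on a Shared Core, and a Third

The source may report more compounds than this note shows. Statements on the series, on what has been measured and on what is new or still open speak of the compounds shown alone.

Compound 1 `O=C(Nc1ccc(Cl)c(-c2nnc3c(Cl)cccn23)c1)c1ccc(C(F)(F)F)cc1Cl` and compound 2 `O=C(Nc1ccc(Cl)c(-c2nnc3c(Cl)cccn23)c1)c1cccc(Cl)c1` share one core and differ only in the aryl group on the carbonyl carbon. In a functional assay on MCF7 cells (Homo sapiens) for antiproliferative activity, read by MTT assay, with a stated time of 72 h (a higher number here means a weaker inhibitor, a lower number a stronger inhibitor), compound 1 gives 81600 nM. In this assay compound 2 gives 71900 nM, the lower of the two numbers, though its nearest neighbour is compound 1 and the gap between them lies within the scatter of the method, so neither can be called the stronger inhibitor on this evidence.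

Compound 3 `O=C(Nc1ccc(Cl)c(-c2nnc3c(Cl)cccn23)c1)c1ccc(Cl)cc1Cl` has not been measured in this assay. It differs from compound 2 in one place: 2,4-dichlorophenyl in place of 3-chlorophenyl on a carbonyl carbon. Among the compounds with values here, no step between measured compounds isolates this exchange. Both measured compounds show very weak inhibition with different aryl groups, and compound 1 carries a chlorine on its aryl group as well, so the author expects compound 3 to stay in the same weak region, with the step from compound 2 to compound 3 being a 1.0-fold higher number from compound 2 to compound 3 (0.02 log units; within the scatter), nothing beyond the scatter. The estimate for compound 3 in this assay is 75000 nM, within a range from 35000 nM to 160000 nM.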

Compound 3, half-maximal inhibitory concentration: 78200 nM
For compound 3 the middle estimate is 1.0-fold (0.02 log units) below the measured one; measured number inside the range.
By their numbers in this assay, from the lowest: compounds 2, 3 and 1 (each within the scatter of the next).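

Within the data shown here, compound 3 supplies the first steps that isolate single exchanges on this aryl group: 2,4-dichlorophenyl in place of 3-chlorophenyl on the carbonyl carbon gives a 1.1-fold higher number from compound 2 to compound 3 (0.04 log units; within the scatter), and chloro in place of trifluoromethyl on an aromatic carbon gives a 1.0-fold lower number from compound 1 to compound 3 (0.02 log units; within the scatter). Neither exchange separates the compounds in this assay, so both single changes leave the numbers in the same very weak region, and no preference among these three chlorinated aryl groups can be stated. No independent evidence bears on this result.

All three aryl groups carry chlorine, so the compounds shown leave open whether an unsubstituted phenyl, or an aryl group bearing an amine or a carboxylic acid, would keep the number in this region. They also leave open whether a change elsewhere on the shared core, rather than on the aryl group attached to the carbonyl carbon, would move the number beyond the scatter.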